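The source may hold more compounds than are shown below. What is called first, only, known or untested is meant among the compounds shown, and "the series" means these compounds.

Measured so far in a functional assay on MCF7 cells (Homo sapiens) for cytotoxicity, read by MTT assay, with a stated time of 72 h; on this read-out higher numbers stand for weaker inhibition and lower numbers for stronger inhibition:
- compound 1 `CCOC(=O)c1c(C)oc2ncnc(Nc3cccc(Br)c3)c12`: > 1000000 nM (a limit of the assay, not a number)
- compound 2 `CCOC(=O)c1c(C)oc2ncnc(Nc3ccccc3)c12`: 851000 nM
- compound 3 `Cc1oc2ncnc(Nc3cccc(Cl)c3)c2c1C(=O)NC(C)C`: 191000 nM

Of the two true numbers, compound 3 has the lower one, and the gap to compound 2 lies beyond the scatter. Moving to compound 4 `CCOC(=O)c1c(C)oc2ncnc(Nc3cccc(Cl)c3)c12` puts ethoxy in place of isopropylamino on a carbonyl carbon. Among the measured compounds shown here, the one measured step, an at least 1.1-fold lower number from compound 1 to compound 2 (0.07 log units; that floor lies within the scatter), puts hydrogen in place of bromo, with ethoxy present on both sides, and so says little about this swap. Since ethoxy compound 2 stands at 851000 nM a clearly higher number is expected in this assay. The expected step is a 4.2-fold higher number from compound 3 to compound 4 (0.62 log units; beyond the scatter). For compound 4 the estimate is 800000 nM, with an expected range of 350000 nM to 1800000 nM.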

Compound 4, half-maximal inhibitory concentration: > 1000000 nM
Compound 4: a limit, no number (the forecaster's own chance of this, stated with the estimate: 30%); middle value at least 1.2-fold (0.09 log units) away from the limit.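

In this assay, the isopropylamino amide and the ethoxy ester can now be compared directly with the same chloro group in place, and the ester is clearly weaker: an at least 5.2-fold higher number from compound 3 to compound 4 (0.71 log units; beyond the scatter). The chloro swap gives an at least 1.1-fold higher number from compound 2 to compound 4 (0.07 log units; that floor lies within the scatter), so it shows no clear effect, and the step from compound 1 to compound 4 cannot be read. Compound 4 gives a limit of the assay, not a number: the limit of > 1000000 nM in this assay, at which 2 of the 4 values shown sit.

With only one amide shown, it stays open whether the gain is general to amides. A methylamino or butylamino group, or a carboxylic acid, at this carbonyl carbon could settle how far it extends.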